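Changing one aryl ring on a shared core

A few compounds are considered here, and "the series" means these few. Any claim that something is new, unique, unknown or untested is made for them only; others in the source may bear on it.

Compound 1, `C=CCn1c(=O)/c(=C\c2cccc(F)c2)[nH]c(=O)/c1=C\c1ccccc1OC`, gives 9100 nM in a functional assay on HeLa cells (Homo sapiens) for cytotoxicity, read by CCK-8 assay, with a stated time of 72 h; a higher number here means a weaker inhibitor, a lower number a stronger inhibitor.
Compound 2, `C=CCn1c(=O)/c(=C\c2ccccc2Cl)[nH]c(=O)/c1=C\c1ccccc1OC`, gives 5100 nM in this assay.
Compound 3, `C=CCn1c(=O)/c(=C\c2ccccc2C(F)(F)F)[nH]c(=O)/c1=C\c1ccccc1OC`, gives 4600 nM in this assay.

All three share one core and differ only in the ring attached to a double-bonded chain carbon. Compound 2 sits second highest of the three numbers; its nearest neighbour is compound 3, with a 1.1-fold lower number from compound 2 to compound 3 (0.04 log units; within the scatter), and its furthest is compound 1, with a 1.8-fold lower number from compound 1 to compound 2 (0.25 log units; within the scatter). Neither gap exceeds the usual scatter, so the three values cannot be ordered with confidence.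

Compound 4, `C=CCn1c(=O)/c(=C\c2cc(F)ccc2C)[nH]c(=O)/c1=C\c1ccccc1OC`, is not yet measured. It differs from compound 2 in this way: 5-fluoro-2-methylphenyl in place of 2-chlorophenyl on a double-bonded chain carbon bound to an aromatic carbon

Going by the values given here, the steps that bear on this change are those swapping the same ring: a 1.8-fold lower number from compound 1 to compound 2 (0.25 log units; within the scatter), a 2.0-fold lower number from compound 1 to compound 3 (0.30 log units; within the scatter) and a 1.1-fold lower number from compound 2 to compound 3 (0.04 log units; within the scatter). Each stays within the scatter, so three different rings at this place have left the number in this assay essentially unchanged. On that basis, no step beyond the scatter is expected from compound 2 to compound 4, which means an expected 1.1-fold higher number from compound 2 to compound 4 (0.03 log units; within the scatter). Compound 4 is therefore estimated at 5500 nM, with a range from 2200 nM to 14000 nM.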

Compound 4, half-maximal inhibitory concentration: 2900 nM
Compound 4: the middle estimate sits 1.9-fold (0.28 log units) above what was measured, and the stated range covers the measured number.
By their numbers in this assay, from the lowest: compounds 4, 3, 2 and 1 (each within the scatter of the next, the first and the last beyond it).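

In this assay, going by these compounds alone, the step of a 3.1-fold lower number from compound 1 to compound 4 (0.50 log units; beyond the scatter) is the first at this position to lie beyond the scatter, if only modestly, whereas all three steps among the earlier compounds stayed within it. Within the data shown here, the change in that step is methyl in place of hydrogen on an aromatic carbon, so the ring at this place can shift the number after all, though only a single pair of compounds shows it. The other two new steps, a 1.8-fold lower number from compound 2 to compound 4 (0.25 log units; within the scatter) and a 1.6-fold lower number from compound 3 to compound 4 (0.20 log units; within the scatter), stay within the scatter, so compound 4 cannot be set apart from compound 2 or compound 3, and the 5-fluoro-2-methylphenyl ring is not shown to be better than the 2-chlorophenyl or 2-(trifluoromethyl)phenyl rings.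

The compounds shown leave open whether a larger shift is possible here, for instance with a ring carrying an amine or a carboxylic acid, and whether the methyl step would repeat on a ring without the fluorine. Nothing available explains why this methyl goes with the step.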